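Indole to Tert-Butylphenyl: an Expected Loss of Potency

This account rests on a few compounds, and the source may have more. Where it says the series, first, only, none or still open, it means among the compounds named here.

Measured so far:
compound 1, `Cn1ccc2cc(-c3cc4nccc(-c5ccc(F)cc5)n4n3)ccc21` — 4580 nM in a functional assay on MCF7 cells (Homo sapiens) for inhibition, read by CCK-8 assay, with a stated time of 48 h; a higher number here means a weaker inhibitor, a lower number a stronger inhibitor
compound 2, `COc1cc(-c2ccnc3cc(-c4ccc5c(ccn5C)c4)nn23)cc(OC)c1OC` — in this assay compound 2 gives 3 nM
compound 3, `Cc1ccc(-c2cc3nccc(-c4ccc(F)cc4)n3n2)cc1` — in this assay compound 3 reaches only a limit, > 10000 nM

Compound 2 holds the lowest of the two numbers shown; its nearest neighbour, compound 1, sits far higher, well beyond the scatter. Compound 3 is known only as a limit (the limit of > 10000 nM in this assay, at which 1 of the 3 values shown sits), so it sets no number.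

Compound 4, `COc1cc(-c2ccnc3cc(-c4ccc(C(C)(C)C)cc4)nn23)cc(OC)c1OC`, differs from compound 2 in one place: 4-(tert-butyl)phenyl in place of 1-methyl-1H-indol-5-yl on an aromatic carbon. Going by the values given here, no measured pair covers this change, so its size is uncertain. Among the compounds with values here, a clear weakening is expected, a 33-fold higher number from compound 2 to compound 4 (1.52 log units; beyond the scatter), since no compound here shows a 4-(tert-butyl)phenyl group. Compound 4 is estimated at 100 nM, with a plausible range from 10 nM to 2000 nM.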

Compound 4, half-maximal inhibitory concentration: > 10000 nM
Compound 4: no number, only a limit; the forecaster's own chance of this, stated with the estimate: 10%; middle value at least 100-fold (2.00 log units) away from the limit.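

Going by these compounds alone, this is the first one-place comparison in the set, and it shows that this aromatic carbon tolerates very little change: 4-(tert-butyl)phenyl in place of 1-methyl-1H-indol-5-yl gives an at least 3300-fold higher number from compound 2 to compound 4 (3.52 log units; beyond the scatter). Both groups have 10 heavy atoms, so group size by that count does not separate them. Compound 4 gives only a limit, not a number: the limit of > 10000 nM in this assay, at which 2 of the 4 values shown sit.

On these data alone, the true size of the step therefore stays open. Also open, as far as these compounds go, is whether a plain phenyl, a phenyl carrying an amine, or an indole without its methyl group would keep any of the potency of compound 2.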